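Coumarin-bearing pyrazoline: chloro replaced by 4-methylpiperazin-1-yl

The compounds below may be only part of what the source reports. "The series", "measured", "known", "first", "only" and "open" are said of these compounds alone.

Measured so far in a functional assay on PC-3 cells (Homo sapiens) for cytotoxicity, read by MTT assay, with a stated time of 48 h; on this read-out lower numbers stand for stronger inhibition and higher numbers for weaker inhibition:
compound 1 `CC1=NN(S(=O)(=O)c2ccc(C)cc2)C(c2cc(Br)cc(Br)c2O)C1`, 51200 nM;
compound 2 `CC(=O)Oc1ccccc1C1CC(C)=NN1C(=O)CN1CCCCC1`, 4070 nM;
compound 3 `O=C(CCl)N1N=C(c2cc3ccccc3oc2=O)CC1c1ccccc1`, 2980 nM.

Compound 3 gives the lowest of the three numbers in this assay. Its nearest neighbour is compound 2, whose value lies within the scatter of repeated measurement, so the two cannot be ranked against each other; compound 1 stands far higher, beyond the scatter.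

Compound 4 `CN1CCN(CC(=O)N2N=C(c3cc4ccccc4oc3=O)CC2c2ccccc2)CC1` is not yet measured. It differs from compound 3 in one place: 4-methylpiperazin-1-yl in place of chloro on a saturated chain carbon bound to a carbonyl carbon.

For the measured compounds named here, no step between measured compounds is available to calibrate this change. Compound 2 carries a cyclic amine on the same kind of carbon and gives 4070 nM, a number close to that of compound 3, so a large shift is not expected. The step from compound 3 to compound 4 in this assay is expected to be a mild weakening, a 2.0-fold higher number from compound 3 to compound 4 (0.30 log units; within the scatter), near the edge of the scatter. Compound 4 is therefore estimated at 6000 nM, with a range from 2000 nM to 20000 nM.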

Compound 4, half-maximal inhibitory concentration: 25800 nM
Estimate against measurement, compound 4: 4.3-fold (0.63 log units) below; the measured number lies above the stated range.
By their numbers in this assay, from the lowest: compounds 3 and 2 (each within the scatter of the next); then compounds 4 and 1 (each within the scatter of the next).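

In this assay, exchanging chloro for 4-methylpiperazin-1-yl on a saturated chain carbon bound to a carbonyl carbon gives an 8.7-fold higher number from compound 3 to compound 4 (0.94 log units; beyond the scatter). This is the first change in a single place among these compounds, and it shows that this position on the shared core is not indifferent to the group it carries, since the step lies beyond the scatter. Nothing available accounts for the size of this step.

The compounds shown leave open whether the change in number follows from the departure of chloro, the six-membered ring or its second nitrogen, and morpholin-4-yl or dimethylamino on the same carbon could help to separate these. From the compounds shown here alone, it also remains open how a longer chain carrying 4-methylpiperazin-1-yl would read in this assay.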